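A few compounds are considered here, and "the series" means these few. Any claim that something is new, unique, unknown or untested is made for them only; others in the source may bear on it.

Measured compounds in a functional assay on HCC1806 cells (Homo sapiens) for inhibition, read by sulforhodamine B assay, tested at 10 uM; on this read-out lower numbers stand for less inhibition and higher numbers for more inhibition at the one concentration tested (going by the name of the read-out):
compound 1 `CN(C)c1ccc(C2CC(c3ccc(-n4cncn4)cc3)=NN2C(=O)c2ccc(F)cc2)cc1` gives 15.6%
compound 2 `CN(C)c1ccc(C2CC(c3ccc(-n4cncn4)cc3)=NN2C(=O)c2cc(Cl)cc(Cl)c2)cc1` gives 5.3%
compound 3 `CN(C)c1ccc(C2CC(c3ccc(-n4cncn4)cc3)=NN2C(=O)c2ccc(C(F)(F)F)cc2)cc1` gives 7%

Compound 3 lies within the scatter of both others: the step of a number 8.6 percentage points lower from compound 1 to compound 3 (within the scatter) and the step of a number 1.7 percentage points higher from compound 2 to compound 3 (within the scatter) are each inside the usual spread. For the measured compounds named here, the only step beyond the scatter is a number 10.3 percentage points lower from compound 1 to compound 2 (beyond the scatter), a modest fall.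

Compound 4 `Cc1ccc(S(=O)(=O)N2N=C(c3ccc(-n4cncn4)cc3)CC2c2ccc(N(C)C)cc2)cc1` differs from compound 3 by (4-methylphenyl)sulfonyl in place of (4-(trifluoromethyl)phenyl)carbonyl on an amine nitrogen in a ring. Going by the values given here, all three measured steps vary the aryl group on the carbonyl; none replaces the carbonyl itself by a sulfonyl, so no direct precedent exists. Since every measured change at this position stayed small, and all three numbers are low, no step beyond the scatter is expected in this assay.

Compound 4 is therefore estimated at 8% (range -5% to 25%), an expected step of a number 1 percentage points higher from compound 3 to compound 4 (within the scatter).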

Compound 4, a percentage reported as inhibition, at one concentration (the size of the read-out at that concentration, not a potency): 27.7%
Beside the measured number, compound 4's estimate is 19.7 percentage points below it; the whole stated range lies below it.
By their numbers in this assay, from the lowest: compounds 2, 3 and 1 (each within the scatter of the next, the first and the last beyond it); then compound 4.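

In this assay, putting (4-methylphenyl)sulfonyl on the amine nitrogen in the ring in place of each arylcarbonyl group raises the number every time: a number 20.7 percentage points higher from compound 3 to compound 4 (beyond the scatter), a number 22.4 percentage points higher from compound 2 to compound 4 (beyond the scatter) and a number 12.1 percentage points higher from compound 1 to compound 4 (beyond the scatter). All three steps are modest, and in each the carbonyl and the aryl group change together, so neither change can be credited alone. No available evidence accounts for the rise.

Still open, as far as these compounds go, is whether (4-methylphenyl)carbonyl or (4-(trifluoromethyl)phenyl)sulfonyl would separate the two changes. Also open, from the compounds shown here alone, is whether methylsulfonyl, with no aromatic ring on the sulfur, would hold the number.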